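The source may hold more compounds than are shown below. What is called first, only, known or untested is meant among the compounds shown, and "the series" means these compounds.

Going by the values given here, in a functional assay on P388 cells (Mus musculus) for antiproliferative activity, read by colorimetric assay and MTT assay (a lower number here means a stronger inhibitor, a higher number a weaker inhibitor), compound 1 `O=[N+]([O-])c1ccc(S(=O)(=O)Nc2cccc3cc(Cl)[nH]c23)cc1` gives 21 ug/mL, the only exact number available so far. Compound 2 `O=[N+]([O-])c1ccc(S(=O)(=O)Nc2cccc3cc(O)[nH]c23)cc1` is reported only as a limit, > 100 ug/mL. Compound 3 `Cc1ccc(S(=O)(=O)Nc2cccc3cc(Cl)[nH]c23)cc1` keeps the chloro group of compound 1 and differs from it by methyl in place of nitro on an aromatic carbon, para to a large group. Among the compounds with values here, the one measured step, an at least 4.7-fold higher number from compound 1 to compound 2 (0.67 log units; beyond the scatter), is hydroxy in place of chloro and lies beyond the scatter. It leaves the nitro group untouched, so it bears on this change only loosely and gives no direction for it. Within the data shown here, no measured step replaces the nitro group, so no shift beyond the scatter is expected in this assay, though the uncertainty is wide. For compound 3 the expected value is 20 ug/mL, with an estimated range from 6 ug/mL to 65 ug/mL. This estimate means an expected 1.1-fold lower number from compound 1 to compound 3 (0.02 log units; within the scatter).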

Compound 3, half-maximal inhibitory concentration: 0.14 ug/mL
Estimate against measurement, compound 3: 140-fold (2.15 log units) above, outside the stated range (below it).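

In this assay, methyl in place of nitro gives a 150-fold lower number from compound 1 to compound 3 (2.18 log units; beyond the scatter), with the chloro group kept. Going by these compounds alone, the only earlier step left the nitro group untouched, so this is the first evidence that the position para to a large group can move the number, and here the change goes strongly towards a stronger inhibitor. The data shown give no cause for this step.

With only nitro and methyl compared at this position, the compounds shown do not reveal whether the step reflects the loss of nitro, the arrival of methyl, or both. They also leave open how an amine, a methoxy group, a carboxylic acid or a longer chain such as ethyl would read there, and whether hydroxy in place of chloro would act the same way with methyl present.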